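A few compounds are considered here, and "the series" means these few. Any claim that something is new, unique, unknown or untested is made for them only; others in the source may bear on it.

Measured compounds in an assay on CHO cells for displacement of a labelled ligand from melanin-concentrating hormone receptor 1 (Rattus norvegicus), read by scintillation counting, with a stated time of 1 h; on this read-out higher numbers stand for weaker inhibition and lower numbers for stronger inhibition:
compound 1 `Cn1c(C2CC2)nc2ccc(-n3ccc(OCc4ccc(Cl)cc4)cc3=O)cc21` 21 nM
compound 2 `CCc1nc2ccc(-n3ccc(OCc4ccc(F)cc4)cc3=O)cc2n1C` 38 nM
compound 3 `Cn1c(C2CC2)nc2ccc(-n3ccc(OCc4ccc(F)cc4)cc3=O)cc21` 28 nM

On these numbers compound 2 gives the highest value of the three in this assay; its nearest neighbour is compound 3, and the step from one to the other is a 1.4-fold lower number from compound 2 to compound 3 (0.13 log units; within the scatter). The remaining step is a 1.3-fold higher number from compound 1 to compound 3 (0.12 log units; within the scatter), so all three values sit within the scatter of one another.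

Compound 4 `Cn1c(CC2CC2)nc2ccc(-n3ccc(OCc4ccc(F)cc4)cc3=O)cc21` differs from compound 2 by cyclopropyl in place of methyl on a saturated chain carbon bound to an aromatic carbon. For the measured compounds named here, the only measured step that bears on a change at this position is the one from compound 2 to compound 3, and it stayed within the scatter. A larger group at the same attachment point is thus expected to give no step beyond the scatter, a 1.2-fold lower number from compound 2 to compound 4 (0.07 log units; within the scatter).

Compound 4 is therefore estimated at 32 nM, with a range of 13 nM to 80 nM.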

Compound 4, half-maximal inhibitory concentration: 140 nM
Beside the measured number, compound 4's estimate is 4.4-fold (0.64 log units) below it; the measured number lies above the stated range.
By their numbers in this assay, from the lowest: compounds 1, 3 and 2 (each within the scatter of the next); then compound 4.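

In this assay, for the compounds shown here, the ethyl and cyclopropyl groups of the earlier compounds gave values within the scatter, whereas cyclopropylmethyl gives the first steps beyond it: a 3.7-fold higher number from compound 2 to compound 4 (0.57 log units; beyond the scatter), and a 5.0-fold higher number from compound 3 to compound 4 (0.70 log units; beyond the scatter). This position is therefore not indifferent to the group it carries, as both routes to cyclopropylmethyl raise the number. Nothing available explains this rise.

Still open, as far as these compounds go, is whether the rise follows the three-membered ring on a saturated chain carbon or the chain alone, which an open propyl or butyl chain could separate. Also open, from the compounds shown here alone, is how a methoxymethyl or aminomethyl group would read at this position.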